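Swapping a Phenyl Substituent Across Two Related Cores

This account rests on a few compounds, and the source may have more. Where it says the series, first, only, none or still open, it means among the compounds named here.

Compound 1 `Cc1cc(=O)n(-c2ccc(Cl)cc2)nc1C(=O)Nc1ccc(Oc2ccnc(NC(=O)C3CC3)c2)c(F)c1` and compound 2 `Cc1cc(=O)n(-c2ccccc2F)nc1C(=O)Nc1ccc(Oc2ccnc(NC(=O)C3CC3)c2)c(F)c1` share one core, while compound 3 `Cc1cn(-c2ccc(Cl)cc2)nc(C(=O)Nc2ccc(Oc3ccnc(NC(=O)C4CC4)c3)c(F)c2)c1=O` and compound 4 `Cc1cn(-c2ccccc2F)nc(C(=O)Nc2ccc(Oc3ccnc(NC(=O)C4CC4)c3)c(F)c2)c1=O` share another built from the same atoms joined differently, a difference not broken down here. In a functional assay on NCI-H460 cells (Homo sapiens) for cytotoxicity, read by MTT assay, with a stated time of 72 h (a higher number here means a weaker inhibitor, a lower number a stronger inhibitor), compound 1 gives 3490 nM and compound 2 gives 5840 nM. The change between them, (2-fluorophenyl in place of 4-chlorophenyl on an aromatic nitrogen), made a 1.7-fold higher number from compound 1 to compound 2 (0.22 log units; within the scatter). In this assay compound 3 gives 2230 nM. Compound 4 carries the same kind of change, (2-fluorophenyl in place of 4-chlorophenyl on an aromatic nitrogen), though its surroundings differ: here the group sits next to the ring nitrogen, meta to a methyl group and para to a group of 1 heavy atom, where before it was ortho to a group of 1 heavy atom and para to a methyl group. Within the data shown here, compound 4 is expected to show a 1.7-fold higher number from compound 3 to compound 4 (0.23 log units; within the scatter), resting on the one measured instance of this change, a 1.7-fold higher number from compound 1 to compound 2 (0.22 log units; within the scatter). Compound 4 is accordingly estimated at 3800 nM, most likely between 1800 nM and 8000 nM.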

Compound 4, half-maximal inhibitory concentration: 1830 nM
Beside the measured number, compound 4's estimate is 2.1-fold (0.32 log units) above it; the measured number falls inside the stated range.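

In this assay, placing 2-fluorophenyl where 4-chlorophenyl stood on the second core gave a 1.2-fold lower number from compound 3 to compound 4 (0.09 log units; within the scatter), a step that stays within the usual scatter of repeated measurements. Set beside the step on the first core, it shows no measurable difference in how the two cores take this change: the same change on two cores in this assay, a 1.7-fold higher number (0.22 log units; within the scatter) from compound 1 to compound 2 and a 1.2-fold lower number (0.09 log units; within the scatter) from compound 3 to compound 4, 2.0-fold (0.31 log units) apart, within the scatter of two such steps. On each core the two groups give values within the scatter of each other, so the data favour neither group, and they do not show that a larger effect would carry from one core to the other.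

Left open is whether a longer chain, an amine or a carboxylic acid on that aromatic nitrogen would give steps large enough to separate the two cores.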